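The source may report more compounds than this note shows. Statements on the series, on what has been measured and on what is new or still open speak of the compounds shown alone.

Working notes on the ester series built on the shared core. Among the measured compounds shown here, compound 1 `CCC(=O)OCCc1c(-c2ccccc2Cl)c2cc(Cl)ccc2[nH]c1=O` gives 95000 nM in an ADME assay on HepG2 2.2.15 cells (Homo sapiens) for cytotoxicity (on this read-out higher numbers stand for lower toxicity in this test and lower numbers for higher toxicity in this test), the highest of the three numbers measured so far. Compound 2 `CCCC(=O)OCCc1c(-c2ccccc2Cl)c2cc(Cl)ccc2[nH]c1=O` gives 52000 nM in this assay, and compound 3 `O=C(OCCc1c(-c2ccccc2Cl)c2cc(Cl)ccc2[nH]c1=O)C1CCCCC1` gives 38000 nM in this assay. The measured steps are a 1.8-fold lower number from compound 1 to compound 2 (0.26 log units; within the scatter) and a 2.5-fold lower number from compound 1 to compound 3 (0.40 log units; beyond the scatter), while a 1.4-fold lower number from compound 2 to compound 3 (0.14 log units; within the scatter).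

Compound 4 `O=C(CCC1CCCCC1)OCCc1c(-c2ccccc2Cl)c2cc(Cl)ccc2[nH]c1=O` remains to be measured in this assay. Against compound 1 the change is cyclohexyl in place of hydrogen on a saturated chain carbon, two bonds along the chain from a carbonyl carbon. For the measured compounds named here, two measured steps bear on it: a 1.8-fold lower number from compound 1 to compound 2 (0.26 log units; within the scatter) places a methyl at the same position, and a 2.5-fold lower number from compound 1 to compound 3 (0.40 log units; beyond the scatter) brings in the same cyclohexyl, at the carbonyl carbon, and is the only step in the set beyond the scatter. Compound 4 carries the longest acyl chain of the four, so a modest move in the same direction is expected, of about the size seen for compound 3 in a 2.5-fold lower number from compound 1 to compound 3 (0.40 log units; beyond the scatter), meaning a 3.0-fold lower number from compound 1 to compound 4 (0.47 log units; beyond the scatter). Compound 4 is therefore estimated at 32000 nM in this assay, with a range from 14000 nM to 70000 nM.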

Compound 4, half-maximal cytotoxic concentration: 160000 nM
Beside the measured number, compound 4's estimate is 5.0-fold (0.70 log units) below it; measured number above the stated range.
By their numbers in this assay, from the lowest: compounds 3, 2, 1 and 4 (each within the scatter of the next, the first and the last beyond it).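

At the saturated chain carbon two bonds along the chain from a carbonyl carbon, cyclohexyl leaves this assay with no change beyond the scatter (a 1.7-fold higher number from compound 1 to compound 4 (0.23 log units; within the scatter)), so a large group is tolerated at this position. Moving the ring out along the chain gives a clear separation from the ring directly on the carbonyl carbon (a 4.2-fold higher number from compound 3 to compound 4 (0.62 log units; beyond the scatter)), and cyclohexyl also separates from methyl at the same position (a 3.1-fold higher number from compound 2 to compound 4 (0.49 log units; beyond the scatter)), so compound 4 goes against any reading of lower numbers with larger acyl groups. Nothing on hand explains these differences.

Open, from the compounds shown here alone, is how the number depends on the length of the link: cyclohexylmethyl on the carbonyl carbon would fill the gap between compound 3 and compound 4. Phenyl or an amine at the same chain position would show whether the result is particular to cyclohexyl.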